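The compounds below may be only part of what the source reports. "The series", "measured", "known", "first", "only" and "open" are said of these compounds alone.

Compound 1: `O=C(CN1CCC(Cc2ccccc2)CC1)Nc1ccc(C(=O)/C=C/c2cn(Cc3ccc(Br)cc3)nn2)cc1`, 54500 nM in a functional assay on MCF7 cells (Homo sapiens) for inhibition, read by MTT assay; a higher number here means a weaker inhibitor, a lower number a stronger inhibitor.
Compound 2: `O=C(CBr)Nc1ccc(C(=O)/C=C/c2cn(Cc3ccc(Br)cc3)nn2)cc1`, 10100 nM.

For the measured compounds named here, of the two compounds measured so far, compound 2 gives the lower number, and compound 1 a higher one; the gap between them lies beyond the usual scatter. Compound 3, `CCCCCCCCn1cc(/C=C/C(=O)c2ccc(NC(=O)CBr)cc2)nn1`, has not yet been measured. It differs from compound 2 in one place: heptyl in place of 4-bromophenyl on a saturated chain carbon bound to an aromatic nitrogen. Going by the values given here, no measured pair shows what this kind of change does here, so the direction is uncertain; a small step, roughly within or just beyond the scatter, is expected, as a 1.5-fold higher number from compound 2 to compound 3 (0.17 log units; within the scatter). Compound 3 is thus estimated at 15000 nM, with a likely range from 5000 nM to 45000 nM.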

Compound 3, half-maximal inhibitory concentration: 12900 nM
The estimate for compound 3 lay 1.2-fold (0.07 log units) above the measured number; the measured number falls inside the stated range.
By their numbers in this assay, from the lowest: compounds 2 and 3 (each within the scatter of the next); then compound 1.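

Heptyl in place of 4-bromophenyl on a saturated chain carbon bound to an aromatic nitrogen gives a 1.3-fold higher number from compound 2 to compound 3 (0.11 log units; within the scatter) in this assay, so the two groups cannot be told apart here. In this single pair, then, the aromatic ring and its bromine are not required for a number at this level. No available evidence accounts for this result.

On these data alone, whether a shorter or longer chain would read the same remains open. So does the effect of an amine or a carboxylic acid at the end of the chain.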